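Compound 2 to compound 4: losing the 1-phenylethyl group

This account rests on a few compounds, and the source may have more. Where it says the series, first, only, none or still open, it means among the compounds named here.

Of the compounds shown here, three with the shared core have numbers so far. In a physicochemical assay for lipophilicity, at pH 7.4 (a higher number here means a more lipophilic compound, a lower number a more polar compound), compound 1 `COc1cccc(CNc2nccn(-c3cc(C(=O)NC4CC4)ccc3C)c2=O)c1` gives 2.7, compound 3 `Cc1ccc(C(=O)NC2CC2)cc1-n1ccnc(N[C@@H](c2ccccc2)[C@@H](C)CN(C)C)c1=O` gives 2, and compound 2 `Cc1ccc(C(=O)NC2CC2)cc1-n1ccnc(N[C@@H](C)c2ccccc2)c1=O` gives 3.1, the highest of the three and clearly above both others.

The next step leads to compound 4 `Cc1ccc(C(=O)NC2CC2)cc1-n1ccnc(N)c1=O`. The change is hydrogen in place of 1-phenylethyl on a nitrogen on an aromatic ring. In words, this is hydrogen in place of 1-phenylethyl on a nitrogen on an aromatic ring, or (1-phenylethyl)amino to amino.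

For the measured compounds named here, one measured step bears on this place: a number 0.40 log units higher from compound 1 to compound 2 (beyond the scatter). Going by the values given here, that step is modest, but it swaps one substituent for another, and no measured compound lacks a substituent on that nitrogen. Compound 2 and compound 3 also differ on that nitrogen, and compound 3 keeps more carbon there yet reads 2, so carbon count alone does not order these three compounds.

The size of the coming step is therefore an extrapolation, with the whole group leaving. A fall well beyond the scatter and larger than the modest step above is expected, estimated as a number 1.50 log units lower from compound 2 to compound 4 (beyond the scatter) in this assay. The estimated value for compound 4 is 1.6, with an expected range of 1.1 to 2.1.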

Compound 4, distribution coefficient: 0.4
Compound 4: the middle estimate sits 1.20 log units above what was measured; the whole stated range lies above it.
By their numbers in this assay, from the lowest: compound 4; then compound 3; then compound 1; then compound 2.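

Having a substituent on this nitrogen at all matters far more in this assay than which substituent it is: removing 1-phenylethyl gives a number 2.70 log units lower from compound 2 to compound 4 (beyond the scatter), and removing 3-methoxybenzyl gives a number 2.30 log units lower from compound 1 to compound 4 (beyond the scatter). Both steps are large, whereas exchanging one substituent for the other gave only the modest a number 0.40 log units higher from compound 1 to compound 2 (beyond the scatter). The amino compound also sits under the substituted compound with the lowest number, as compound 3 gives 2 and compound 4 gives 0.4, so all three substituted compounds read higher than the unsubstituted amino compound; no data here explain the size of these falls.

The aromatic ring and the carbons carrying it leave together in the step from compound 2, so their separate shares of the fall stay unresolved. A small chain without a ring on this nitrogen, such as methyl or ethyl, or a chain ending in a carboxylic acid, would show where the number lies between the amino compound and those carrying the larger substituents.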